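The source may hold more compounds than are shown below. What is called first, only, known or untested is meant among the compounds shown, and "the series" means these compounds.

Measured so far:
compound 1 `C#CCNC1CCc2c(SCc3cccc(F)c3)cccc21`, compound 2 `C#CCNC1CCc2c(SCc3ccc(C)cc3)cccc21`, compound 3 `C#CCNC1CCc2c(SCc3cccc(Cl)c3)cccc21`.

In an assay on isolated protein for inhibition of Amine oxidase [flavin-containing] B (Homo sapiens) (a higher number here means a weaker inhibitor, a lower number a stronger inhibitor), compound 1 gives 1480 nM, compound 2 gives 1560 nM and compound 3 gives 23300 nM. Compound 3 therefore carries the highest number of the three and is the weakest inhibitor here, with the steps of a 16-fold higher number from compound 1 to compound 3 (1.20 log units; beyond the scatter) and a 15-fold higher number from compound 2 to compound 3 (1.17 log units; beyond the scatter) both beyond the scatter.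

Compound 4 `C#CCNC1CCc2c(SCc3cccc(Br)c3)cccc21` differs from compound 3 by bromo in place of chloro on an aromatic carbon. Going by the values given here, the only measured step at that same aromatic carbon, a 16-fold higher number from compound 1 to compound 3 (1.20 log units; beyond the scatter), was a large weakening when one halogen replaced another; no measured pair compares chloro with bromo, so the direction of this second halogen swap is uncertain. Compound 4 is therefore expected to stay near compound 3 in this assay, at roughly 30000 nM, with a likely range from 8000 nM to 120000 nM. That estimate corresponds to an expected step of a 1.3-fold higher number from compound 3 to compound 4 (0.11 log units; within the scatter).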

Compound 4, half-maximal inhibitory concentration: > 100000 nM
Compound 4: a limit, no number; the forecaster's own chance of this, stated with the estimate: 15%; middle value at least 3.3-fold (0.52 log units) away from the limit.
By their numbers in this assay, from the lowest: compounds 1 and 2 (each within the scatter of the next); then compound 3. At a limit, above all of these: compound 4.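

Going from fluoro through chloro to bromo on this aromatic carbon weakens inhibition at each swap, and the move to bromo gives an at least 4.2-fold higher number from compound 3 to compound 4 (0.63 log units; beyond the scatter), so the effect of the halogen here continues past chloro. Measured against the other two compounds, the 3-bromophenyl compound shows an at least 64-fold higher number from compound 2 to compound 4 (1.80 log units; beyond the scatter) and an at least 67-fold higher number from compound 1 to compound 4 (1.82 log units; beyond the scatter). Compound 4 gives a limit rather than a number: the limit of > 100000 nM in this assay, at which 1 of the 4 values shown sits.

As far as these compounds go, how far compound 4 lies past that limit stays unknown, so the true size of these steps is open. Also open, from the compounds shown here alone, is whether a methoxy group or an amine on this same aromatic carbon would follow the halogens.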